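A few compounds are considered here, and "the series" means these few. Any claim that something is new, unique, unknown or untested is made for them only; others in the source may bear on it.

Working notes on the series in a functional assay on thoracic aorta (Rattus norvegicus, strain Wistar), with a stated time of 15 min; a higher number here means that more compound is needed for the effect, a lower number that less compound is needed. Compound 2 `CCOc1ccc(F)cc1C(C)NC(=O)N(C)S(=O)(=O)c1ccc(C)cc1` carries a methyl on an amide-type nitrogen, and in this assay compound 2 gives 7800 nM. Compound 1 `CCOc1ccc(F)cc1C(C)NC(=O)NS(=O)(=O)c1ccc(C)cc1` is the hydrogen counterpart; in this assay compound 1 reaches only a limit, > 300000 nM. The change hydrogen in place of methyl on an amide-type nitrogen therefore makes an at least 38-fold higher number from compound 2 to compound 1 (1.58 log units; beyond the scatter), the size being bounded by the limit of > 300000 nM in this assay, at which 1 of the 3 values shown sits. Compound 3 `CC(NC(=O)N(C)S(=O)(=O)c1ccccc1)c1ccccc1OCc1ccccc1` keeps the methylated nitrogen on another core; the difference between the core of compound 3 and that of compound 2 is not broken down here. In this assay compound 3 gives 21700 nM, a higher number than compound 2. Compound 4 `CC(NC(=O)NS(=O)(=O)c1ccccc1)c1ccccc1OCc1ccccc1` is the hydrogen counterpart of compound 3, made by the same change, (hydrogen in place of methyl on an amide-type nitrogen), at a place described in the same words. Given an at least 38-fold higher number from compound 2 to compound 1 (1.58 log units; beyond the scatter), the step expected here is a 37-fold higher number from compound 3 to compound 4 (1.57 log units; beyond the scatter), and the result is expected to sit at or beyond the limit (the limit of > 300000 nM in this assay, at which 1 of the 3 values shown sits). Compound 4 is thus estimated at 800000 nM, between 150000 nM and 4000000 nM.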

Compound 4, half-maximal effective concentration: > 200000 nM
Compound 4: only a limit was reported (the forecaster's own chance of this, stated with the estimate: 80%); the middle value lies beyond the limit too.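

In this assay, hydrogen in place of methyl on the amide-type nitrogen gives an at least 9.2-fold higher number from compound 3 to compound 4 (0.96 log units; beyond the scatter), so the direction seen on the core of compound 2 recurs on the core of compound 3. The value of compound 4, > 200000 nM, is a limit, which makes this step a bound and not a measured size. The two cores therefore agree in direction, but nothing here shows that the size of the step carries over from one core to the other: the same change on two cores in this assay, an at least 38-fold higher number (1.58 log units; beyond the scatter) from compound 2 to compound 1 and an at least 9.2-fold higher number (0.96 log units; beyond the scatter) from compound 3 to compound 4; the limit leaves it open whether they differ

The compounds shown leave open whether an ethyl group or a longer chain on the same nitrogen would give a number close to that of the methyl compounds or one nearer to that of the hydrogen compounds. Also open is whether the change behaves in the same way on a core carrying an amine or a carboxylic acid, since only two cores are shown here.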